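Fluoro for chloro on the aryl of compound 3

The source may report more compounds than this note shows. Statements on the series, on what has been measured and on what is new or still open speak of the compounds shown alone.

Compound 3 `O=C(c1ccc(F)cc1)N1CC(c2nc(-c3cccc(Cl)c3)no2)C1` has no number in an assay on HEK293 cells for positive allosteric modulation of metabotropic glutamate receptor 5 (Homo sapiens), read by FLIPR; on this read-out lower numbers stand for an effect already at smaller amounts and higher numbers for an effect only at larger amounts of compound: its result is a limit, > 10000 nM. That limit, (the limit of > 10000 nM in this assay, at which 1 of the 3 values shown sits), is the only point known for this compound. Compound 4 `O=C(c1ccc(F)cc1)N1CC(c2nc(-c3cccc(F)c3)no2)C1` differs from it by fluoro in place of chloro on an aromatic carbon. Among the compounds with values here, no measured step covers this exchange. Within the data shown here, the single measured step, a 44-fold higher number from compound 1 to compound 2 (1.65 log units; beyond the scatter), concerns the group on the carbonyl of the shared core, not the aryl; compound 1 `O=C([C@H]1CC2CCC1C2)N1CC(c2nc(-c3cccc(F)c3)no2)C1` gives 72 nM and compound 2 `O=C(c1ccc(F)c(F)c1)N1CC(c2nc(-c3cccc(F)c3)no2)C1` gives 3200 nM, both carrying the same 3-fluorophenyl as compound 4. Compound 2 at least shows that this aryl, paired with an aromatic group on the carbonyl, can return a number in this assay. For compound 4 the expected step is an at least 1.6-fold lower number from compound 3 to compound 4 (0.22 log units; that floor lies within the scatter), out of the limit into the measurable range, though a further limit remains possible. The estimate for compound 4 is 6000 nM, with a range from 2000 nM to 20000 nM.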

Compound 4, half-maximal effective concentration: 2400 nM
Beside the measured number, compound 4's estimate is 2.5-fold (0.40 log units) above it; the measured number falls inside the stated range.
By their numbers in this assay, from the lowest: compound 1; then compounds 4 and 2 (each within the scatter of the next). At a limit, above all of these: compound 3.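

In this assay, 3-chlorophenyl to 3-fluorophenyl on the aryl gives an at least 4.1-fold lower number from compound 3 to compound 4 (0.61 log units; beyond the scatter), so this position does respond to the exchange, with the size read only as a floor. Compound 3 remains a limit: the limit of > 10000 nM in this assay, at which 1 of the 4 values shown sits.

On the carbonyl, hydrogen in place of fluoro on the aromatic group makes no readable difference, a 1.3-fold lower number from compound 2 to compound 4 (0.12 log units; within the scatter), whereas the bridged group of compound 1 keeps its distance from a second aromatic group, a 33-fold higher number from compound 1 to compound 4 (1.52 log units; beyond the scatter).

From the compounds shown here alone, the aryl exchange is read here with one carbonyl group only, so its size with the group of compound 1 stays open. Also open, going by these compounds, is how a methoxy or a nitrile would fare on the aryl, or a cyclohexyl on the carbonyl.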